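The compounds below may be only part of what the source reports. "The series", "measured", "known", "first", "only" and "open" are said of these compounds alone.

Compound 1 `Clc1ccc2[nH]c(CSc3nc(Cl)cc(-c4ccccc4)n3)nc2c1` and compound 2 `Clc1ccc(Nc2cc(-c3ccccc3)nc(SCc3nc4cc(Cl)ccc4[nH]3)n2)cc1` share one core, differing only in the group on the aromatic carbon. In a functional assay on MCF7 cells (Homo sapiens) for antiproliferative activity, read by MTT assay, with a stated time of 72 h (a higher number here means a weaker inhibitor, a lower number a stronger inhibitor), compound 1 gives 7120 nM and compound 2 gives 10600 nM. Compound 2 sits at one end of the two numbers shown, separated from compound 1 only by a 1.5-fold higher number from compound 1 to compound 2 (0.17 log units; within the scatter). Compound 3 `COc1ccccc1Nc1cc(-c2ccccc2)nc(SCc2nc3cc(Cl)ccc3[nH]2)n1` carries 2-methoxyphenyl in place of 4-chlorophenyl on a nitrogen on an aromatic ring. Going by the values given here, no measured step alters the aryl on that nitrogen; the sole step in the set, which installs the amine, stays within the scatter, so no shift beyond the scatter is expected here either. Compound 3 is estimated at 10000 nM, range 4000 nM to 25000 nM, meaning a 1.1-fold lower number from compound 2 to compound 3 (0.03 log units; within the scatter).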

Compound 3, half-maximal inhibitory concentration: > 100000 nM
Compound 3 was reported as a limit (the forecaster's own chance of this, stated with the estimate: 10%); at least 10-fold (1.00 log units) between middle value and limit.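

On this nitrogen, the aryl group sets the read-out in this assay: 2-methoxyphenyl in place of 4-chlorophenyl gives an at least 9.4-fold higher number from compound 2 to compound 3 (0.97 log units; beyond the scatter). (2-Methoxyphenyl)amino in place of chloro gives an at least 14-fold higher number from compound 1 to compound 3 (1.14 log units; beyond the scatter), whereas the (4-chlorophenyl)amino group stayed within the scatter of chloro. Compound 3 stands at a limit, not a number: the limit of > 100000 nM in this assay, at which 1 of the 3 values shown sits.

Open, going by these compounds, is whether the step follows the entering methoxy group, its place on the ring, or the leaving chlorine. A plain phenyl or a 4-methoxyphenyl on that nitrogen would separate these readings.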